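One arm exchanged, cytotoxicity in HEL cells expected unchanged

The source may report more compounds than this note shows. Statements on the series, on what has been measured and on what is new or still open speak of the compounds shown alone.

Compound 1 `O=C(COc1cccc2ccccc12)N/N=C/c1ccccc1Br` gives >= 20 ug/mL in an ADME assay on HEL cells (Homo sapiens) for cytotoxicity; on this read-out higher numbers stand for lower toxicity in this test and lower numbers for higher toxicity in this test.
Compound 2 `C/C(=N\NC(=O)COc1cccc2ccccc12)c1ccc(O)cc1O` gives > 100 ug/mL in this assay.

Compound 1 stands at the limit of >= 20 ug/mL in this assay, at which 1 of the 2 values shown sits, which is a limit of the assay rather than a measured number. Compound 2 sits at the limit of > 100 ug/mL in this assay, at which 1 of the 2 values shown sits, likewise a limit and not a number. For the measured compounds named here, the two measured compounds share a core and differ in more than one place, so no single step between them can be read.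

Compound 3 `O=C(COc1cccc2ccccc12)N/N=C/C=C/c1ccccc1` is not yet measured. It differs from compound 1 by 2-phenylethenyl in place of 2-bromophenyl on a carbon with a double bond to nitrogen. With both measured values only limits, nothing in the data points to a change in either direction, so the step that the limit leaves unreadable from compound 1 to compound 3 is expected to lie within the usual scatter, and most likely only a limit will again be reported. Compound 3 is estimated at 50 ug/mL in this assay, expected to fall between 20 ug/mL and 100 ug/mL.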

Compound 3, minimum cytotoxic concentration: 100 ug/mL
Estimate against measurement, compound 3: 2.0-fold (0.30 log units) below; the measured number falls inside the stated range.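

The step between compound 1 and compound 3 cannot be read, because compound 1 is known only as a limit and not as a number: the limit of >= 20 ug/mL in this assay, at which 1 of the 3 values shown sits.

The compounds shown leave open whether 2-phenylethenyl in place of 2-bromophenyl shifts the result in this assay at all.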